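Swapping a Chain on a Well-Tolerated Compound

The compounds below may be only part of what the source reports. "The series", "measured", "known", "first", "only" and "open" are said of these compounds alone.

In an ADME assay on HeLa cells (Homo sapiens) for cytotoxicity, read by ATP content, with a stated time of 3 days (a higher number here means that more compound is tolerated, a lower number that less compound is tolerated), compound 2 (`CC(C)CCn1c(Cn2c(=O)n(C3CC3)c3ccncc32)nc2nc(Cl)ccc21`) gives > 50000 nM, which is a limit of the assay and not a number. Compound 3 (`CS(=O)(=O)CCCn1c(Cn2c(=O)n(C3CC3)c3ccncc32)nc2nc(Cl)ccc21`) replaces its isopentyl with 3-(methylsulfonyl)propyl ((methylsulfonyl)methyl in place of isopropyl on a saturated chain carbon, two bonds along the chain from an aromatic nitrogen). Compound 1 (`CS(=O)(=O)CCCn1c(Cn2c(=O)n(C3CC3)c3ccncc32)cc2cc(Cl)ccc21`) carries that same chain, and its > 50000 nM is also a limit, so good tolerance is expected to hold. In this assay, the expected change is a number no higher from compound 2 to compound 3 (the limit leaves the size open), which would be nothing beyond the usual scatter. Compound 3 is estimated at 50000 nM, with an expected range from 25000 nM to 100000 nM.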

Compound 3, half-maximal cytotoxic concentration: > 50000 nM
Compound 3: no number, only a limit; the forecaster's own chance of this, stated with the estimate: 90%; the middle value sits exactly at the limit.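

No step can be read from compound 2 to compound 3, because each gives only a limit and not a number: the limit of > 50000 nM in this assay, at which 3 of the 3 values shown sit.

The compounds shown leave open whether exchanging isopentyl for 3-(methylsulfonyl)propyl changes tolerance at all.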